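The source may hold more compounds than are shown below. What is called first, only, known or untested is meant among the compounds shown, and "the series" means these compounds.

Of the compounds shown here, two that share a core have been measured in an assay on BV-2 cells for positive allosteric modulation of metabotropic glutamate receptor 5 (Mus musculus), read by Griess assay, with stated times of 1 h and 24 h; a lower number here means a stronger inhibitor, a higher number a weaker inhibitor. In this assay compound 1 `O=C(Nc1ccccc1F)[C@H]1C[C@@H]1c1cccc(F)c1` gives 210000 nM. In this assay compound 2 `O=C(Nc1ccc(F)cc1)[C@H]1C[C@@H]1c1cccc(F)c1` gives 160000 nM, which sits at the low end of the two numbers, yet its gap to compound 1 is within the scatter, so the two cannot be told apart. Compound 3 `O=C(Nc1ccc(F)cc1)[C@H]1C[C@@H]1c1cccc(Cl)c1` differs from compound 2 by chloro in place of fluoro on an aromatic carbon. Within the data shown here, no measured step bears on this change, so the expected shift is a 1.3-fold lower number from compound 2 to compound 3 (0.12 log units; within the scatter), hardly beyond the scatter. Compound 3 is therefore estimated at 120000 nM, within 50000 nM to 300000 nM.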

Compound 3, half-maximal inhibitory concentration: 58000 nM
Compound 3: the middle estimate sits 2.1-fold (0.32 log units) above what was measured; the measured number falls inside the stated range.
By their numbers in this assay, from the lowest: compound 3; then compounds 2 and 1 (each within the scatter of the next).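

In this assay, chloro in place of fluoro on an aromatic carbon, meta to a large group, gives a 2.8-fold lower number from compound 2 to compound 3 (0.44 log units; beyond the scatter). This is the first change among these compounds that separates two numbers beyond the scatter, so this position responds to the group it carries, even though the step is modest. Nothing at hand explains the shift.

Going by these compounds, whether bromo, methyl or methoxy at this position would move the number further remains open. So does whether chloro would give a similar step with the fluoro placed as in compound 1.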